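Extending the Aromatic Alkyl Chain: Compound 2 to Compound 3

This account rests on a few compounds, and the source may have more. Where it says the series, first, only, none or still open, it means among the compounds named here.

Compound 1 `CCc1cc(C)c(C(=O)N=C(N)N)cc1S(C)(=O)=O` gives 4.8 nM in a functional assay for inhibition of sodium/hydrogen exchanger (Oryctolagus cuniculus); a higher number here means a weaker inhibitor, a lower number a stronger inhibitor. Compound 2 `CCC(C)c1cc(C)c(C(=O)N=C(N)N)cc1S(C)(=O)=O` gives 8 nM in this assay, and the step of a 1.7-fold higher number from compound 1 to compound 2 (0.22 log units; within the scatter) shows that this chain growth left the number where the scatter of repeat measurements would put it. Among the two measured numbers, the values of compound 2 and compound 1 lie within the scatter of each other, so neither can be called the weaker or the stronger inhibitor.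

Compound 3 `CCCCCc1cc(C)c(C(=O)N=C(N)N)cc1S(C)(=O)=O` has not yet been measured in this assay. It differs from compound 2 by pentyl in place of sec-butyl on an aromatic carbon. For the measured compounds named here, the only measured step that bears on such a change at this position is the one from compound 1 to compound 2, and it stayed within the scatter. On that ground the step of a 1.1-fold higher number from compound 2 to compound 3 (0.05 log units; within the scatter) is expected to be small, with no direction beyond the scatter. Compound 3 is therefore estimated to give about 9 nM in this assay, with a range from 3.5 nM to 24 nM.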

Compound 3, half-maximal inhibitory concentration: 27 nM
Beside the measured number, compound 3's estimate is 3.0-fold (0.48 log units) below it; measured number outside the range, above it.
By their numbers in this assay, from the lowest: compounds 1 and 2 (each within the scatter of the next); then compound 3.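

In this assay, for the compounds shown here, the step of a 3.4-fold higher number from compound 2 to compound 3 (0.53 log units; beyond the scatter) is the first change at this aromatic carbon, ortho to a methylsulfonyl group, to lie beyond the scatter, so the position does not accept every alkyl group alike. The two chains grown from compound 1 also part ways: a 1.7-fold higher number from compound 1 to compound 2 (0.22 log units; within the scatter) stays within the scatter with the branched sec-butyl, while a 5.6-fold higher number from compound 1 to compound 3 (0.75 log units; beyond the scatter) lies beyond it with the unbranched pentyl, so the number depends on more than the presence of a larger alkyl group. The data offer no measured property or other finding that accounts for this rise.

The step from sec-butyl to pentyl both adds a carbon and removes the branch, so the compounds shown cannot separate the contribution of chain length from that of branching; an unbranched butyl or propyl group at this position would bear directly on that question. On these data alone, it also remains open whether the number keeps rising with a longer chain such as hexyl, and how a cyclopentyl ring, which holds the same number of carbons as pentyl, would compare.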